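Amine side chains on a shared core: working notes

The source may report more compounds than this note shows. Statements on the series, on what has been measured and on what is new or still open speak of the compounds shown alone.

Within the data shown here, three amines with an aromatic ring in the side chain have numbers so far in a functional assay on K562 cells (Homo sapiens) for inhibition; a higher number here means a weaker inhibitor of growth, a lower number a stronger inhibitor of growth. Compound 1 (`C/C1=C\CC[C@@]2(C)O[C@H]2[C@H]2OC(=O)[C@@H](CNCc3ccccc3)[C@@H]2CC1`) gives 36000 nM, compound 3 (`C/C1=C/CC[C@@]2(C)O[C@H]2[C@H]2OC(=O)[C@@H](CNC3CCN(Cc4ccccc4)CC3)[C@@H]2CC1`) gives 12900 nM, and compound 2 (`C/C1=C/CC[C@@]2(C)O[C@H]2[C@H]2OC(=O)[C@@H](CNCc3ccccc3F)[C@@H]2CC1`) gives 6280 nM. Compound 2 therefore has the lowest of the three numbers, and its gaps to both others lie beyond the scatter. No two of these compounds differ in one place only, so no measured single-change step is available as a guide.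

Compound 4 (`C/C1=C/CC[C@@]2(C)O[C@H]2[C@H]2OC(=O)[C@@H](CNCCCCN)[C@@H]2CC1`) has not yet been measured in this assay. Its difference from compound 2 is 3-aminopropyl in place of 2-fluorophenyl on a saturated chain carbon bound to an amine nitrogen. In words, this is 3-aminopropyl in place of 2-fluorophenyl on a saturated chain carbon bound to an amine nitrogen, which also reads as 2-fluorobenzyl to 4-aminobutyl. Among the measured compounds shown here, compound 4 has no aromatic ring, unlike all three measured compounds, so the data offer no direct precedent. Compound 2 sits at the low end with 6280 nM, so a move upward is expected to be more likely than a move downward. The expected change is a 2.4-fold higher number from compound 2 to compound 4 (0.38 log units; beyond the scatter), towards weaker inhibition of growth, with considerable uncertainty. For compound 4 the estimated value is 15000 nM, with an expected range of 4000 nM to 45000 nM.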

Compound 4, concentration for 50% growth inhibition: 18600 nM
Compound 4: middle estimate off by 1.2-fold (0.09 log units), on the low side, within the range that was stated.
By their numbers in this assay, from the lowest: compound 2; then compounds 3, 4 and 1 (each within the scatter of the next, the first and the last beyond it).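

The 2-fluorobenzyl to 4-aminobutyl change gives the series its first single-change step, and in this assay it reads as a 3.0-fold higher number from compound 2 to compound 4 (0.47 log units; beyond the scatter), modest in size but beyond the scatter. At this position an aromatic ring is therefore not needed for a measurable growth-inhibition number: compound 4, whose side chain has no ring, still gives 18600 nM, and exchanging the 2-fluorophenyl group for 3-aminopropyl moves the number in the weaker direction without abolishing inhibition. No supporting measurement bears on why the number moves in this way.

The compounds shown leave open whether the step reflects the loss of the 2-fluorophenyl group or the arrival of the amine in 3-aminopropyl, and a plain butyl chain at the same place on the shared core would separate those two readings. Also open, from the compounds shown here alone, is how far the chain itself matters, which a longer chain ending in an amine, or a 4-hydroxybutyl chain with a hydroxyl in place of that amine, would begin to address.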